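Adding a Methyl Group to the Weaker Mirror Image

The compounds below may be only part of what the source reports. "The series", "measured", "known", "first", "only" and "open" are said of these compounds alone.

Measured compounds:
compound 1, `c1cncc(N2CC[C@H]3CN[C@H]3C2)c1`, 48 nM
compound 2, `c1cncc(N2CC[C@@H]3CN[C@@H]3C2)c1`, 260 nM

In a functional assay on HEK293 cells for agonist activity at Neuronal acetylcholine receptor; alpha3/beta4 (Homo sapiens), read by FLIPR (a lower number here means that less compound is needed, a higher number that more compound is needed for the effect), compound 1 gives 48 nM, and its mirror image compound 2 gives 260 nM. Compound 2 therefore has the higher of the two numbers, meaning more of it is needed to reach the half-maximal effect. For the measured compounds named here, the only measured step is a 5.4-fold higher number from compound 1 to compound 2 (0.73 log units; beyond the scatter), and it rests solely on (the fact that compounds 1 and 2 differ only in the configuration as drawn).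

Compound 3, `Cc1cncc(N2CC[C@@H]3CN[C@@H]3C2)c1`, is made from compound 2 by methyl in place of hydrogen on an aromatic carbon. The methyl enters on an aromatic carbon of a six-membered aromatic ring with 1 nitrogen, two atoms from the ring nitrogen, with the rest of the molecule untouched. Going by the values given here, no measured pair of compounds differs by such a methyl group, so the single measured step, a 5.4-fold higher number from compound 1 to compound 2 (0.73 log units; beyond the scatter), which concerns configuration only, does not bear on this change. With nothing measured pointing up or down, the expected step in this assay is none beyond the scatter. Compound 3 is estimated at 260 nM, in the range 90 nM to 750 nM. This estimate means the step of no change at the digits printed from compound 2 to compound 3 (within the scatter), expected to stay within the scatter.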

Compound 3, half-maximal effective concentration: 1400 nM
Estimate against measurement, compound 3: 5.4-fold (0.73 log units) below, outside the stated range (above it).
By their numbers in this assay, from the lowest: compound 1; then compound 2; then compound 3.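

In this assay, methyl in place of hydrogen on an aromatic carbon, two atoms from the ring nitrogen, gives a 5.4-fold higher number from compound 2 to compound 3 (0.73 log units; beyond the scatter), so at least in compound 2 this position does not tolerate even this small group without a cost. Compounds 1 and 2 showed only that the configuration of the shared core moves the number, whereas this step shows that the aromatic ring matters too, with a single added carbon moving the number beyond the scatter and towards more compound being needed for the effect. The one available fact about these compounds concerns configuration alone, so it offers no explanation for the effect of the methyl group.

The compounds shown leave open whether the higher number is specific to methyl or would also follow from a different group at this position, such as a fluorine atom, a methoxy group or an amine. They also leave open whether the same methyl group would raise the number on the mirror-image core of compound 1, or whether the effect holds only for the configuration of compound 2.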